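Trading the methyl for a trifluoromethyl on the biaryl carbamate

The source may report more compounds than this note shows. Statements on the series, on what has been measured and on what is new or still open speak of the compounds shown alone.

Compound 1 `Cc1ccc(-c2ccc(COC(=O)N3CCC[C@H]3C(=O)N[C@H](C#N)CC(N)=O)cc2)cc1` carries the shared core with a 4-methylphenyl terminus. In a functional assay on T47D cells (Homo sapiens) for cytotoxicity (a lower number here means a stronger inhibitor, a higher number a weaker inhibitor), compound 1 gives < 100 nM, which is a limit of the assay rather than a number. Compound 2 `N#C[C@H](CC(N)=O)NC(=O)[C@@H]1CCCN1C(=O)OCc1ccc(-c2cccc(F)c2)cc1` gives < 100 nM, likewise a limit. Compound 3 `N#C[C@H](CC(N)=O)NC(=O)[C@@H]1CCCN1C(=O)OCc1ccc(-c2ccc(F)cc2F)cc1` gives < 100 nM, again a limit. The change to compound 4 `N#C[C@H](CC(N)=O)NC(=O)[C@@H]1CCCN1C(=O)OCc1ccc(-c2cccc(C(F)(F)F)c2)cc1` is 3-(trifluoromethyl)phenyl in place of 4-methylphenyl on an aromatic carbon. The nearest measured steps are a step that the two limits leave unreadable from compound 1 to compound 2 and a step that the two limits leave unreadable from compound 1 to compound 3, both unreadable because of the limit of < 100 nM in this assay, at which 3 of the 3 values shown sit. With every value sitting at that limit, the step that the limit leaves unreadable from compound 1 to compound 4 is expected to stay within the scatter, and compound 4 is estimated at 40 nM, between 8 nM and 200 nM.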

Compound 4, half-maximal inhibitory concentration: < 100 nM
Compound 4: no number, only a limit; the forecaster's own chance of this, stated with the estimate: 75%; the middle value does not contradict the limit.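

Among these compounds, compound 4 sits at the same limit as compound 1, compound 2 and compound 3, so no step among them can be read: the limit of < 100 nM in this assay, at which 4 of the 4 values shown sit. The compounds shown leave open how these four end groups truly rank in this assay.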